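A few compounds are considered here, and "the series" means these few. Any claim that something is new, unique, unknown or untested is made for them only; others in the source may bear on it.

Measured so far:
- compound 1 `COc1ccc2[nH]c(C(=O)N[C@H](CCCNC(=N)N)C(=O)NCc3ccc(C(F)(F)F)cc3)cc2c1`: 78 nM
- compound 2 `N=C(N)NCCC[C@@H](NC(=O)c1ccc2ccccc2n1)C(=O)NCc1ccc(C(F)(F)F)cc1`: 904 nM

Both numbers come from a functional assay on HEK293 cells for antagonist activity at melanin-concentrating hormone receptor 1 (Homo sapiens); on this read-out higher numbers stand for weaker inhibition and lower numbers for stronger inhibition. Within the data shown here, compound 2 gives the highest of the two numbers; its nearest neighbour is compound 1, and the one measured step, a 12-fold higher number from compound 1 to compound 2 (1.06 log units; beyond the scatter), is large and beyond the scatter.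

Compound 3 `N=C(N)NCCC[C@@H](NC(=O)c1ccc(F)c2ccccc12)C(=O)NCc1ccc(C(F)(F)F)cc1` has not been measured. The change from compound 2 is 4-fluoronaphthalen-1-yl in place of quinolin-2-yl on a carbonyl carbon. Among the measured compounds shown here, no measured step concerns this change: the only step available swaps the indole-type group for quinolin-2-yl, not quinolin-2-yl for 4-fluoronaphthalen-1-yl, so it offers no direct guide to direction. What the two values show is that the group on this carbonyl carbon can move the read-out by a large amount.

Given that, compound 3 is expected to differ from compound 2 only moderately, with direction uncertain and a wide range, as a step of a 2.3-fold lower number from compound 2 to compound 3 (0.35 log units; beyond the scatter). The estimate for compound 3 in this assay is 400 nM, within 80 nM to 2000 nM.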

Compound 3, half-maximal inhibitory concentration: 311 nM
For compound 3 the middle estimate is 1.3-fold (0.11 log units) above the measured one; low and high end bracket the measured number.
By their numbers in this assay, from the lowest: compound 1; then compound 3; then compound 2.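

In this assay, the group on this carbonyl carbon can be changed from quinolin-2-yl to a ring system of carbon only carrying fluorine with a gain in inhibition, as a 2.9-fold lower number from compound 2 to compound 3 (0.46 log units; beyond the scatter) shows. The gain does not reach the level of 5-methoxy-1H-indol-2-yl, with a 4.0-fold higher number from compound 1 to compound 3 (0.60 log units; beyond the scatter) remaining, so among these three groups the order from strongest to weakest inhibition is 5-methoxy-1H-indol-2-yl, 4-fluoronaphthalen-1-yl, quinolin-2-yl. No supporting data bear on why the three groups fall in this order.

The step from quinolin-2-yl to 4-fluoronaphthalen-1-yl removes the ring nitrogen and adds fluorine together, so the share of each stays unresolved. The compounds shown leave open where an unsubstituted naphthalen-1-yl group or a 5-chloro-1H-indol-2-yl group would fall on this read-out.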